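Aryl amine changes on the shared core

A few compounds are considered here, and "the series" means these few. Any claim that something is new, unique, unknown or untested is made for them only; others in the source may bear on it.

Values in a functional assay on MGC-803 cells (Homo sapiens) for inhibition, read by sulforhodamine B assay; on this read-out higher numbers stand for weaker inhibition and lower numbers for stronger inhibition:
- compound 1 `O=C1C=C(NC2CCCC2)C(=O)c2c1nc1n2[C@H]2OC[C@@H](O)[C@H]2OC1`: > 8000 nM
- compound 2 `CCOc1ccc(NC2=CC(=O)c3nc4n(c3C2=O)[C@H]2OC[C@@H](O)[C@H]2OC4)cc1`: 1110 nM
- compound 3 `CCOc1ccccc1NC1=CC(=O)c2nc3n(c2C1=O)[C@H]1OC[C@@H](O)[C@H]1OC3`: 2450 nM

Compound 1 stands only as a limit of the assay, > 8000 nM. Of the two true numbers, compound 3 is the higher at 2450 nM, and compound 2 is lower at 1110 nM.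

Compound 4 `O=C1C=C(Nc2cccc(Cl)c2)C(=O)c2c1nc1n2[C@H]2OC[C@@H](O)[C@H]2OC1` differs from compound 3 by 3-chlorophenyl in place of 2-ethoxyphenyl on an amine nitrogen. Replacing cyclopentyl with an aryl group gave an at least 7.2-fold lower number from compound 1 to compound 2 (0.85 log units; beyond the scatter) and an at least 3.2-fold lower number from compound 1 to compound 3 (0.51 log units; beyond the scatter), both measured against the limit. Among the measured compounds shown here, the closest precedent is the only step among aryl groups, a 2.2-fold higher number from compound 2 to compound 3 (0.34 log units; beyond the scatter), which is modest. For the measured compounds named here, no chlorophenyl compound has been measured. On that precedent, no step beyond the scatter is expected in this assay, and no direction is favoured. The estimated change is a 1.2-fold lower number from compound 3 to compound 4 (0.09 log units; within the scatter). For compound 4 the expected value is 2000 nM, with an estimated range of 700 nM to 6000 nM.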

Compound 4, half-maximal inhibitory concentration: 1770 nM
Compound 4: middle estimate off by 1.1-fold (0.05 log units), on the high side; low and high end bracket the measured number.
By their numbers in this assay, from the lowest: compounds 2, 4 and 3 (each within the scatter of the next, the first and the last beyond it). At a limit, above all of these: compound 1.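

In this assay an ethoxy group on the phenyl ring is not required at this position: with 3-chlorophenyl on the amine nitrogen there is a 1.4-fold lower number from compound 3 to compound 4 (0.14 log units; within the scatter) and a 1.6-fold higher number from compound 2 to compound 4 (0.20 log units; within the scatter) and neither step lies beyond the scatter. Compound 4 thus sits within the scatter of both ethoxyphenyl compounds, although those two lie beyond the scatter of each other. A third aryl group also stands apart from cyclopentyl, with an at least 4.5-fold lower number from compound 1 to compound 4 (0.65 log units; beyond the scatter) as a step read against a limit: the limit of > 8000 nM in this assay, at which 1 of the 4 values shown sits.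

Substituent identity and ring placement remain unseparated, as chloro and ethoxy do not share a ring placement here; 4-chlorophenyl or 3-ethoxyphenyl would separate them. Also open, from the compounds shown here alone, is whether a pyridine ring or a benzyl group on the amine nitrogen would keep the aryl values.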